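This account rests on a few compounds, and the source may have more. Where it says the series, first, only, none or still open, it means among the compounds named here.

Compound 1 `Cc1ccc(N2CCCC2)c(C(=O)Nc2ccc(CNC(=O)OCc3cccnc3)cc2)c1`: 40600 nM
Compound 2 `COc1ccc(N2CCCC2)c(C(=O)Nc2ccc(CNC(=O)OCc3cccnc3)cc2)c1`: 35600 nM

Among the measured compounds shown here, in a toxicity assay on WI-38 cells (Homo sapiens) for inhibition, read by MTT assay, with a stated time of 72 h (on this read-out lower numbers stand for stronger inhibition and higher numbers for weaker inhibition), compound 2 gives 35600 nM, and its only measured neighbour, compound 1, gives 40600 nM. The two lie within the scatter of each other, so compound 2 stands level with compound 1 on these numbers.

The next compound, compound 3 `O=C(NCc1ccc(NC(=O)c2cc(Cl)ccc2N2CCCC2)cc1)OCc1cccnc1`, has chloro in place of methoxy on an aromatic carbon, meta to a large group and para to a pyrrolidin-1-yl group: chloro in place of methoxy on an aromatic carbon.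

For the measured compounds named here, only one measured step bears on this change. It concerns the same aromatic carbon, where methoxy replaces methyl, and it gives a 1.1-fold lower number from compound 1 to compound 2 (0.06 log units; within the scatter). That step stays within the scatter. Going by the values given here, no measured compound carries chloro, however, so this evidence is indirect and the range has to stay wide. On this single step, no change beyond the scatter is expected in this assay, and no direction can be claimed. The expected change is a 1.1-fold lower number from compound 2 to compound 3 (0.03 log units; within the scatter). For compound 3 the estimated value is 33000 nM, with an expected range from 16000 nM to 65000 nM.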

Compound 3, half-maximal inhibitory concentration: > 100000 nM
Compound 3: no number, only a limit; the forecaster's own chance of this, stated with the estimate: 10%; at least 3.0-fold (0.48 log units) between middle value and limit.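

In this assay compound 3 gives > 100000 nM, which is a limit of the assay and not a number. Methoxy in place of methyl on this aromatic carbon gave a 1.1-fold lower number from compound 1 to compound 2 (0.06 log units; within the scatter), whereas chloro in place of methoxy gives an at least 2.8-fold higher number from compound 2 to compound 3 (0.44 log units; beyond the scatter) and chloro in place of methyl gives an at least 2.4-fold higher number from compound 1 to compound 3 (0.39 log units; beyond the scatter), so the carbon para to a pyrrolidin-1-yl group does respond to what it carries, a point that compound 1 and compound 2 alone gave no sign of. Both new steps are lower bounds only, and how far compound 3 actually lies from the other two cannot be told from a limit: the limit of > 100000 nM in this assay, at which 1 of the 3 values shown sits.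

The three compounds shown leave open whether the shift belongs to chloro in particular or would also appear with fluoro, bromo, a nitrile or an amine on this carbon. They also leave open whether chloro on another carbon of the same ring would give a step of this kind.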